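The source may hold more compounds than are shown below. What is called first, only, known or untested is meant among the compounds shown, and "the series" means these compounds.

Measured so far in a functional assay (Homo sapiens) for antiproliferative activity, read by resazurin assay, with a stated time of 48 h, tested at 10 uM; on this read-out higher numbers stand for a stronger effect at the one concentration tested and lower numbers for a weaker effect:
compound 1 `COc1cc(OC)c2c(=O)cc(-c3ccc(OCCN4CCCC4=O)cc3)oc2c1` 14%
compound 2 `COc1cc(OC)c2c(=O)cc(-c3ccc(OC4CCNCC4)cc3)oc2c1` 21%
compound 3 `COc1cc(OC)c2c(=O)cc(-c3ccc(OCC(O)CN4CCCC4)cc3)oc2c1` 37%

Compound 3 stands highest of the three; its nearest neighbour is compound 2, via a number 16 percentage points higher from compound 2 to compound 3 (beyond the scatter), and compound 1 lies furthest, via a number 23 percentage points higher from compound 1 to compound 3 (beyond the scatter). Compounds 1 and 2 are within the scatter of each other, a number 7 percentage points higher from compound 1 to compound 2 (within the scatter).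

Compound 4 `COc1cc(OC)c2c(=O)cc(-c3ccc(NCCN(C)C)cc3)oc2c1` is not yet measured. Its change from compound 3 is (2-(dimethylamino)ethyl)amino in place of 2-hydroxy-3-(pyrrolidin-1-yl)propoxy on an aromatic carbon, on an aromatic carbon of a six-membered aromatic ring of carbon only.

Both steps into compound 3 show that what sits on this aromatic carbon can move this assay by a modest, beyond-scatter amount; none of them swaps the oxygen attachment for a nitrogen one, so the direction is open. Compound 4 is expected to give 25%, range 8% to 42%, a step of a number 12 percentage points lower from compound 3 to compound 4 (beyond the scatter), estimated as a modest fall toward the values of compounds 1 and 2.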

Compound 4, a percentage reported as inhibition, at one concentration (the size of the read-out at that concentration, not a potency): 60%
Compound 4: the middle estimate sits 35 percentage points below what was measured; measured number outside the range, above it.
By their numbers in this assay, from the lowest: compounds 1 and 2 (each within the scatter of the next); then compound 3; then compound 4.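

In this assay, replacing each oxygen-linked group on this aromatic carbon with (2-(dimethylamino)ethyl)amino gives a higher number: (a number 23 percentage points higher from compound 3 to compound 4 (beyond the scatter)), (a number 39 percentage points higher from compound 2 to compound 4 (beyond the scatter)) and (a number 46 percentage points higher from compound 1 to compound 4 (beyond the scatter)). A nitrogen attachment carrying an open chain is therefore compatible with a clear rise at this position, and the two larger steps exceed any step among the oxygen-linked compounds. No evidence available here accounts for the rise.

Each step changes the attachment atom and the side chain together, leaving their contributions unseparated. The 2-(dimethylamino)ethoxy group would isolate the attachment atom, while a longer chain or terminal pyrrolidine would probe the side chain.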